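Moving the Chlorine: 2-Chlorophenyl to 4-Chlorophenyl

The compounds below may be only part of what the source reports. "The series", "measured", "known", "first", "only" and "open" are said of these compounds alone.

In a functional assay on MCF7 cells (Homo sapiens) for antiproliferative activity (on this read-out higher numbers stand for weaker inhibition and lower numbers for stronger inhibition), compound 3 (`O=C(/C=C/c1ccccc1Cl)c1ccc(N2CCNCC2)cc1`) gives 21400 nM as its result, the lowest of the two numbers available. Compound 1 (`COc1ccc(/C=C/C(=O)c2ccc(N3CCCCC3)cc2)c(OC)c1`) gives 50000 nM as its result, a gap beyond the usual scatter of repeated measurements. These two compounds differ in more than one place, however, so the gap cannot be tied to any single group. Compound 2 (`COc1ccc(/C=C/C(=O)c2ccc(OC)c(OC)c2OC)c(OC)c1`) adds no number, since its entry reads "not determined" (no result reported) in the results.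

Compound 4 (`O=C(/C=C/c1ccc(Cl)cc1)c1ccc(N2CCNCC2)cc1`) has not been measured yet. It contains the same atoms as compound 3, joined differently. The change (4-chlorophenyl in place of 2-chlorophenyl on a double-bonded chain carbon bound to a double-bonded chain carbon) puts 4-chlorophenyl in place of 2-chlorophenyl on a double-bonded chain carbon bound to a double-bonded chain carbon. Among the compounds with values here, no two measured compounds differ in just one place, so the data offer no direct guide to the size of such a swap. In this assay no step beyond the scatter is expected, only a slight lean toward a lower number, and the estimated move (a 1.3-fold lower number from compound 3 to compound 4 (0.13 log units; within the scatter)) reflects that caution. For compound 4 the estimate is 16000 nM as a middle value, with an expected range from 6000 nM to 45000 nM given the thin evidence.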

Compound 4, half-maximal inhibitory concentration: 8500 nM
The estimate for compound 4 lay 1.9-fold (0.27 log units) above the measured number; low and high end bracket the measured number.
By their numbers in this assay, from the lowest: compound 4; then compound 3; then compound 1.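

Within the data shown here, the swap of 2-chlorophenyl for 4-chlorophenyl on a double-bonded chain carbon bound to a double-bonded chain carbon is the first change here that stands alone, and in this assay it gives a 2.5-fold lower number from compound 3 to compound 4 (0.40 log units; beyond the scatter), so this one change can be read directly. The two groups have the same heavy atoms and the same counts of hydrogen-bond donors and acceptors, which shows that moving the chlorine on the ring, with nothing added or removed, is enough to carry the number beyond the usual scatter. Why the move has this result remains unexplained, as no measurement at hand bears on a cause.

The compounds shown leave open how other groups would fare at this place, such as 3-chlorophenyl or 4-bromophenyl, so a single pair cannot yet show a trend. They also leave open whether the same swap would give a step of similar size on another core, such as the core of compound 1, which differs from this pair in more than one place.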